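This account rests on a few compounds, and the source may have more. Where it says the series, first, only, none or still open, it means among the compounds named here.

Compound 1 `COc1ccc(CN(C(=O)CSc2nc3ccccc3o2)c2cc(OC)c(OC)c(OC)c2)cc1` gives 3280 nM in a functional assay on HCT-116 cells (Homo sapiens) for inhibition, read by CCK-8 assay, with a stated time of 48 h (a higher number here means a weaker inhibitor, a lower number a stronger inhibitor), the lowest of the two numbers in hand. Compound 2 `COc1ccc(CN(C(=O)CSC(=S)N2CCc3cc(Br)ccc32)c2cc(OC)c(OC)c(OC)c2)cc1` gives 8060 nM in this assay. Compound 3 `COc1ccc(CN(C(=O)CN2CCN(C(C)=O)CC2)c2cc(OC)c(OC)c(OC)c2)cc1` differs from compound 1 by 4-acetylpiperazin-1-yl in place of (1,3-benzoxazol-2-yl)sulfanyl on a saturated chain carbon bound to a carbonyl carbon. Among the measured compounds shown here, only one measured step touches this position: a 2.5-fold higher number from compound 1 to compound 2 (0.39 log units; beyond the scatter), where one ring pair replaced another on the sulfur. Because a 2.5-fold higher number from compound 1 to compound 2 (0.39 log units; beyond the scatter) already shows a loss of potency for that swap, and compound 3 removes the (1,3-benzoxazol-2-yl)sulfanyl group entirely, a somewhat larger loss is expected, a 2.7-fold higher number from compound 1 to compound 3 (0.44 log units; beyond the scatter). Compound 3 is therefore estimated at 9000 nM, within 3000 nM to 30000 nM.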

Compound 3, half-maximal inhibitory concentration: > 20000 nM
Compound 3 gave a limit, no number (the forecaster's own chance of this, stated with the estimate: 15%); middle value at least 2.2-fold (0.34 log units) from the limit.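

Putting 4-acetylpiperazin-1-yl in place of (1,3-benzoxazol-2-yl)sulfanyl on a saturated chain carbon bound to a carbonyl carbon gives an at least 6.0-fold higher number from compound 1 to compound 3 (0.78 log units; beyond the scatter). Where the earlier step changed only the ring pair on the sulfur, this change also removes the sulfur, and the number still rises. Compound 3 stands only as a limit in this assay: the limit of > 20000 nM in this assay, at which 1 of the 3 values shown sits.

From the compounds shown here alone, whether a phenyl ring on the sulfur would hold the value of compound 1 stays open. So does the effect of a simple amine or a carboxylic acid on that chain carbon.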